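Working notes: a shorter group on the aromatic nitrogen

The source may report more compounds than this note shows. Statements on the series, on what has been measured and on what is new or still open speak of the compounds shown alone.

Of the compounds shown here, three share one core and have been read in a functional assay with Alpha-1A adrenergic receptor (Homo sapiens) as the target, read by calcium flux; a higher number here means a larger maximal response, a lower number a smaller maximal response. Compound 1 `CC(C)n1ncnc1-c1ccccc1NCC1=NCCN1` gives 104%, the highest of the three numbers. Compound 2 `CCn1cccc1-c1ccccc1NCC1=NCCN1` gives 93%, a number lower than that of compound 1 by a margin beyond the scatter. Compound 3 `CCn1ccc(-c2ccccc2NCC2=NCCN2)n1` gives 78%, the number furthest from compound 1, again beyond the scatter. No two of these compounds differ in only one place, so no single measured step can be drawn from them.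

Compound 4 `Cn1ncnc1-c1ccccc1NCC1=NCCN1` has not yet been measured. It differs from compound 1 in one place: methyl in place of isopropyl on an aromatic nitrogen. The change touches only the group on the aromatic nitrogen of the five-membered aromatic ring with 3 nitrogen, while the rest of the shared core stays as in compound 1. Within the data shown here, with no comparable measured step available, a small change is expected, most likely none beyond the scatter, and the step from compound 1 to compound 4 is estimated as a number 6 percentage points lower from compound 1 to compound 4 (within the scatter). For compound 4 the expected value in this assay is 98%, within a range from 80% to 112%.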

Compound 4, largest response reached (reported as maximal response), in percent of the reference or control that the assay uses: 91%
Beside the measured number, compound 4's estimate is 7 percentage points above it, and the stated range covers the measured number.
By their numbers in this assay, from the lowest: compound 3; then compounds 4 and 2 (each within the scatter of the next); then compound 1.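

Among these compounds, replacing isopropyl with methyl on the aromatic nitrogen gives the first step that can be read from a change in one place: in this assay it is a number 13 percentage points lower from compound 1 to compound 4 (beyond the scatter). The group on this nitrogen therefore bears on the maximal response, although with methyl there compound 4 still gives 91%, so the larger group is not needed for a sizeable response. No available data bear on the reason for this step.

As far as these compounds go, two groups at one position give a single step and no trend, so it stays open whether the response follows the size of the group or whether a longer chain, such as butyl, would raise or lower it. Equally open, from the compounds shown here alone, is how a chain ending in an amine or a carboxylic acid would read at this nitrogen.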